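Isopropyl in Place of Chloro: Estimating Compound 4

This account rests on a few compounds, and the source may have more. Where it says the series, first, only, none or still open, it means among the compounds named here.

Three measured compounds share one core. Compound 1 `O=C(/C=C/c1ccccc1)c1cccc(NC(=O)c2cc(-c3ccncc3)n[nH]2)c1` gives 67100 nM in a functional assay, read by spectrophotometry, tested at 100 uM; on this read-out higher numbers stand for weaker inhibition and lower numbers for stronger inhibition. Compound 2 `O=C(/C=C/c1ccc(Cl)cc1)c1cccc(NC(=O)c2cc(-c3ccncc3)n[nH]2)c1` gives 63900 nM, and compound 3 `COc1ccccc1/C=C/C(=O)c1cccc(NC(=O)c2cc(-c3ccncc3)n[nH]2)c1` gives 41700 nM. Compound 2 holds the second highest of the three numbers, yet a 1.1-fold lower number from compound 1 to compound 2 (0.02 log units; within the scatter) and a 1.5-fold lower number from compound 2 to compound 3 (0.19 log units; within the scatter) both fall within the scatter, so the three stand level. Compound 4 `CC(C)c1ccc(/C=C/C(=O)c2cccc(NC(=O)c3cc(-c4ccncc4)n[nH]3)c2)cc1` differs from compound 2 by isopropyl in place of chloro on an aromatic carbon. Within the data shown here, the measured steps on that ring, a 1.1-fold lower number from compound 1 to compound 2 (0.02 log units; within the scatter) and a 1.6-fold lower number from compound 1 to compound 3 (0.21 log units; within the scatter), moved nothing beyond the scatter, and no measured step exchanges chloro for isopropyl. Compound 4 is therefore expected to show a 1.2-fold lower number from compound 2 to compound 4 (0.07 log units; within the scatter), nothing beyond the scatter. For compound 4 the estimate is 55000 nM, expected to lie between 25000 nM and 120000 nM.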

Compound 4, half-maximal inhibitory concentration: 52300 nM
Compound 4: middle estimate off by 1.1-fold (0.02 log units), on the high side; low and high end bracket the measured number.
By their numbers in this assay, from the lowest: compounds 3, 4, 2 and 1 (each within the scatter of the next).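

In this assay, isopropyl in place of chloro on an aromatic carbon, para to a large group, gives a 1.2-fold lower number from compound 2 to compound 4 (0.09 log units; within the scatter). Isopropyl in place of hydrogen gives a 1.3-fold lower number from compound 1 to compound 4 (0.11 log units; within the scatter), and 4-isopropylphenyl in place of 2-methoxyphenyl gives a 1.3-fold higher number from compound 3 to compound 4 (0.10 log units; within the scatter), so this position accepts isopropyl, with 3 heavy atoms where chloro has 1, without any step beyond the scatter. Nothing measured here bears on the reason for this result. The compounds shown leave open whether an amine, a carboxylic acid or a longer chain at this position would move the number beyond the scatter.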